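The source may report more compounds than this note shows. Statements on the series, on what has been measured and on what is new or still open speak of the compounds shown alone.

Compound 3 `N#Cc1ccc(Cc2ccc3c(NCCCNCc4ccco4)ccnc3c2)cc1` is one of three close relatives measured in a physicochemical assay for acid dissociation; in it compound 3 gives 9.47. Its companions are compound 1 `CC(C)Cc1ccc2c(NCCCNCc3ccco3)ccnc2c1`, which gives 9.47, and compound 2 `c1coc(CNCCCNc2ccnc3cc(CC4CCCCC4)ccc23)c1`, which gives 9.47. All three share the same core and differ only in the group hanging from one saturated chain carbon: the step from compound 1 to compound 2 shows no change at the digits printed from compound 1 to compound 2 (within the scatter), from compound 1 to compound 3 no change at the digits printed from compound 1 to compound 3 (within the scatter), and from compound 2 to compound 3 no change at the digits printed from compound 2 to compound 3 (within the scatter). So swapping isopropyl, cyclohexyl or 4-cyanophenyl at that spot left the proton's readiness to leave untouched.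

Compound 4 `c1coc(CNCCCNc2ccnc3cc(-c4cccc5ccccc45)ccc23)c1` changes the same region more boldly: naphthalen-1-yl in place of 4-cyanobenzyl on an aromatic carbon. Among the compounds with values here, this time the aromatic group is attached directly to the aromatic carbon rather than through a chain carbon, which none of the measured steps covers. Even so, with every measured swap in this region giving no change, the expected step from compound 3 to compound 4 is no change at the digits printed from compound 3 to compound 4 (within the scatter), none beyond the scatter. Compound 4 is therefore estimated at 9.47, between 9.15 and 9.8.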

Compound 4, acid dissociation constant: 9.47
Estimate against measurement, compound 4: no gap at the digits printed, within the range that was stated.
By their numbers in this assay, from the lowest: compounds 1, 2, 3 and 4 (each within the scatter of the next).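

In this assay, setting naphthalen-1-yl directly on the aromatic carbon gives no change at the digits printed from compound 3 to compound 4 (within the scatter) and also no change at the digits printed from compound 2 to compound 4 (within the scatter) and no change at the digits printed from compound 1 to compound 4 (within the scatter). The earlier compounds shown here only exchanged groups held on a saturated chain carbon, whereas compound 4 shows a level reading even with that chain carbon gone and two six-membered aromatic rings of carbon only attached directly at this place. No supporting information is available to explain why these exchanges leave the reading level.

Open, from the compounds shown here alone, is whether a group of a different kind on this aromatic carbon, such as an amine or a carboxylic acid, would also leave the reading level. Changes elsewhere on the shared core also remain open.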